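Methoxy to Acetoxy on a Bile Acid Receptor Binder

This account rests on a few compounds, and the source may have more. Where it says the series, first, only, none or still open, it means among the compounds named here.

In an assay on isolated protein with Bile acid receptor (Homo sapiens) as the target (on this read-out lower numbers stand for an effect already at smaller amounts and higher numbers for an effect only at larger amounts of compound), compound 1 `COC(=O)/C=C/c1cccc(N(Cc2ccc(/C=C/c3ccc(F)cc3)cc2)C(=O)NC(C)C)c1` gives 348 nM. Compound 2 `COC/C=C/c1ccc(CN(C(=O)C2CCCCC2)c2cccc(/C=C/C(=O)OC)c2)cc1` gives 233 nM in this assay. Compound 3 `COC(=O)/C=C/c1cccc(N(Cc2ccc(/C=C/C(=O)OC(C)(C)C)cc2OC)C(=O)C2CCCCC2)c1` is reported in this assay only as > 1000 nM, which is a limit of the measurement and not a number. Compound 3 therefore sits at the limit of > 1000 nM in this assay, at which 1 of the 3 values shown sits, the weaker side of the range covered here.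

Compound 4 `COC(=O)/C=C/c1cccc(N(Cc2ccc(/C=C/C(=O)OC(C)(C)C)cc2OC(C)=O)C(=O)C2CCCCC2)c1` has not yet been measured. It differs from compound 3 in one place: acetyl in place of methyl on an oxygen on an aromatic ring. Going by the values given here, no pair of measured compounds differs by this same change, so there is nothing to compare the step against directly. Because compound 3 stands at the limit of > 1000 nM in this assay, at which 1 of the 3 values shown sits, the starting point itself is not a firm number. The step that the limit leaves unreadable from compound 3 to compound 4 is expected to be small, not beyond the usual scatter, in either direction. Compound 4 is expected to give about 2500 nM in this assay, within a range from 900 nM to 7000 nM.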

Compound 4, half-maximal effective concentration: > 1000 nM
Compound 4: a limit, no number; the forecaster's own chance of this, stated with the estimate: 65%; the middle value is on the limit's open side.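

Going by these compounds alone, compound 3 and compound 4 are both reported in this assay only as limits and not as numbers, and no step between them can be read. The compounds shown leave open whether acetoxy in place of methoxy changes the read-out at all.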